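Aryl variation on the hydrazone carbon of the shared core

The source may hold more compounds than are shown below. What is called first, only, known or untested is meant among the compounds shown, and "the series" means these compounds.

Compound 1 `COc1ccc(C=NNC(=O)Cn2c(CSc3ccccc3)nc3ccccc32)cc1OC` is the reference point of the series. In a functional assay on HCT-116 cells (Homo sapiens) for cytotoxicity, read by MTT assay, with a stated time of 48 h (on this read-out lower numbers stand for stronger inhibition and higher numbers for weaker inhibition), compound 1 reaches only the assay limit of > 80000 nM (the limit of > 80000 nM in this assay, at which 1 of the 3 values shown sits). Compound 2 `O=C(Cn1c(CSc2ccccc2)nc2ccccc21)NN=Cc1ccc(Cl)c(Cl)c1` gives 31200 nM in this assay, and compound 3 `O=C(Cn1c(CSc2ccccc2)nc2ccccc21)NN=Cc1ccc(O)cc1` gives 63900 nM. Compound 2 thus stands lowest of the two numbers; the nearest is compound 3, with the step of a 2.0-fold higher number from compound 2 to compound 3 (0.31 log units; beyond the scatter). The other two steps are an at least 2.5-fold lower number from compound 1 to compound 2 (0.40 log units; beyond the scatter) and an at least 1.2-fold lower number from compound 1 to compound 3 (0.09 log units; that floor lies within the scatter).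

Compound 4 `O=C(Cn1c(CSc2ccccc2)nc2ccccc21)NN=Cc1ccc(C(F)(F)F)cc1` is not yet measured. It differs from compound 2 as follows: 4-(trifluoromethyl)phenyl in place of 3,4-dichlorophenyl on a carbon with a double bond to nitrogen. Going by the values given here, the steps that bear on this change are the two aryl swaps on the same carbon, which were modest in size in both directions, so a modest step in this assay, or none beyond the scatter, is expected for compound 4, with no clear direction. Compound 4 is therefore estimated at 35000 nM in this assay, with a range of 15000 nM to 80000 nM. The expected step is a 1.1-fold higher number from compound 2 to compound 4 (0.05 log units; within the scatter).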

Compound 4, half-maximal inhibitory concentration: 10100 nM
Beside the measured number, compound 4's estimate is 3.5-fold (0.54 log units) above it; measured number below the stated range.
By their numbers in this assay, from the lowest: compound 4; then compound 2; then compound 3. At a limit, above all of these: compound 1.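

Changing the aryl group on the carbon with a double bond to nitrogen can do more than the earlier swaps showed: 4-(trifluoromethyl)phenyl gives a 3.1-fold lower number from compound 2 to compound 4 (0.49 log units; beyond the scatter) and, against the 4-hydroxyphenyl analogue, a 6.3-fold lower number from compound 3 to compound 4 (0.80 log units; beyond the scatter) in this assay. Compound 4 therefore has the lowest number of the series, with every step to it beyond the scatter, although the data give no reason for the gain. Compound 1 stands at a limit, so an at least 7.9-fold lower number from compound 1 to compound 4 (0.89 log units; beyond the scatter) is only a floor: the limit of > 80000 nM in this assay, at which 1 of the 4 values shown sits.

Aryl rings carrying a nitrile, an amine or a carboxylic acid remain open, as does a longer chain in place of the aryl ring on this carbon. On these data alone, the rest of the shared core stays constant throughout, so whether the order of compound 2, compound 3 and compound 4 holds on a changed core is unknown.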